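Cyclopropyl for 3-methoxyphenyl on a ring nitrogen

The source may hold more compounds than are shown below. What is called first, only, known or untested is meant among the compounds shown, and "the series" means these compounds.

Of the compounds shown here, three have been read in a functional assay on HepG2 cells (Homo sapiens) for antiproliferative activity, read by MTT assay, with a stated time of 72 h; on this read-out lower numbers stand for stronger inhibition and higher numbers for weaker inhibition. Compound 1 (`COc1cccc(N2C(=O)COc3ccc(-c4cnc5ccccc5c4)cc32)c1`) gives 2080 nM. A sulfonamide is absent from compound 1 but present in compound 3 (`O=C1COc2ccc(-c3cnc(Cl)c(NS(=O)(=O)c4ccc(F)cc4)c3)cc2N1c1ccc(Cl)cc1`), which gives 33900 nM.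

Compound 2 (`COc1cccc(N2C(=O)COc3ccc(-c4cccc(NS(=O)(=O)c5ccc(F)cc5)c4)cc32)c1`), which also carries a sulfonamide, reads > 40000 nM, a limit of the assay and not a number. For compound 2 the record is therefore (the limit of > 40000 nM in this assay, at which 1 of the 3 values shown sits).

The step of interest leads from compound 2 to compound 4 (`O=C1COc2ccc(-c3cccc(NS(=O)(=O)c4ccc(F)cc4)c3)cc2N1C1CC1`), with cyclopropyl in place of 3-methoxyphenyl on an amide-type nitrogen in a ring.

Going by the values given here, no two measured compounds differ in one place only, so the size of this exchange in this assay has not been seen directly. Only a modest step is expected, possibly towards a somewhat lower number, and it may not exceed the usual scatter. The nearest numerical guide is compound 3 at 33900 nM, which suggests that inhibition will remain weak. The estimated change is an at least 1.3-fold lower number from compound 2 to compound 4 (0.12 log units; that floor lies within the scatter). Compound 4 is expected to give 30000 nM. The estimated range for compound 4 runs from 11000 nM to 60000 nM.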

Compound 4, half-maximal inhibitory concentration: > 40000 nM
Compound 4: only a limit was reported (the forecaster's own chance of this, stated with the estimate: 50%); at least 1.3-fold (0.12 log units) between middle value and limit.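

In this assay compound 4 gives > 40000 nM, a limit of the assay and not a number. No step from compound 2 to compound 4 can be read, as both compounds stand at a limit: the limit of > 40000 nM in this assay, at which 2 of the 4 values shown sit.

The compounds shown leave open how cyclopropyl and 3-methoxyphenyl on the ring nitrogen compare in this assay.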